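The source may report more compounds than this note shows. Statements on the series, on what has been measured and on what is new or still open speak of the compounds shown alone.

Among the compounds with values here, compound 1, `COC(=O)c1cc(C2=C(c3cc(OC)c(OC)c(OC)c3)C(=O)CC2O[SiH2]C(C)(C)C)ccc1OC`, is one of three compounds measured in an ADME assay on MIA PaCa-2 cells (Homo sapiens) for cytotoxicity, read by MTT assay, with a stated time of 72 h; a lower number here means a stronger inhibitor, a higher number a weaker inhibitor. In this assay compound 1 gives > 100 ug/mL, which is a limit of the assay rather than a number. Compound 2, `COc1ccc(C2=C(c3cc(OC)c(OC)c(OC)c3)C(=O)C(OC(C)=O)C2)cc1OC(C)C`, gives > 100 ug/mL, again a limit. Compound 3, `COc1cc(C2=C(c3ccc(OCC(=O)O)cc3)C(O)CC2=O)cc(OC)c1OC`, gives > 100 ug/mL, also a limit.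

Compound 1 therefore stands nowhere in particular among the numbers shown: there are no numbers, only limits, and it sits with the others at the limit of > 100 ug/mL in this assay, at which 3 of the 3 values shown sit. Within the data shown here, no two of the three measured compounds differ in a single place, so no measured step is available to scale from, and the three values say only that none of them inhibited the cells within the range of the assay.

Compound 4, `COc1cc(C2=C(c3ccccc3)C(O[SiH2]C(C)(C)C)CC2=O)cc(OC)c1OC`, is the compound not yet measured. It differs from compound 1 by phenyl in place of 4-methoxy-3-(methoxycarbonyl)phenyl on a double-bonded ring carbon. The shared core of compound 1 and compound 4 is otherwise kept.

With every measured value a limit, the most that can be expected is that compound 4 behaves like compound 1, and the step of a number no higher from compound 1 to compound 4 (the limit leaves the size open) is estimated as none beyond the scatter. Compound 4 is accordingly estimated at 100 ug/mL, with a range from 30 ug/mL to 300 ug/mL, and it is expected that this assay will most likely again report only a limit for compound 4.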

Compound 4, half-maximal inhibitory concentration: > 100 ug/mL
Compound 4: only a limit was reported; the forecaster's own chance of this, stated with the estimate: 75%; the middle value lies on the limit itself.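

Compound 1 and compound 4 are both reported only as limits in this assay, so no step between them can be read: the limit of > 100 ug/mL in this assay, at which 4 of the 4 values shown sit.

The compounds shown leave open how strongly any of them inhibits the cells, and whether phenyl in place of 4-methoxy-3-(methoxycarbonyl)phenyl makes any difference in this assay.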